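The source may hold more compounds than are shown below. What is called first, only, known or untested is meant among the compounds shown, and "the series" means these compounds.

Working notes on the series. Compound 1 `CN(c1cccc2c1CCCC2c1c[nH]cn1)S(C)(=O)=O`, compound 2 `CCCS(=O)(=O)Nc1cccc2c1CCCC2c1c[nH]cn1` and compound 3 `Oc1cccc2c1CCCC2c1c[nH]cn1` share one core and differ only in the group on the aromatic carbon. In an assay on isolated protein (Cricetulus griseus) for binding affinity to Alpha-1B adrenergic receptor (Mesocricetus auratus), read by radioligand binding (on this read-out higher numbers stand for weaker inhibition and lower numbers for stronger inhibition), compound 1 gives < 10000 nM, which is a limit of the assay and not a number. In this assay compound 2 gives < 10000 nM, again a limit. In this assay, among the compounds with values here, compound 3 gives 145 nM, the only number in the set; the other two values sit at the limit of < 10000 nM in this assay, at which 2 of the 3 values shown sit. The steps a step that the limit leaves unreadable from compound 1 to compound 3 and a step that the limit leaves unreadable from compound 2 to compound 3 therefore cannot be sized. Compound 4 `Nc1cccc2c1CCCC2c1c[nH]cn1` is unmeasured; its change is amino in place of hydroxy on an aromatic carbon. Within the data shown here, no measured step bears on this exchange, so no direction is supported. Compound 4 is expected near 300 nM, within 60 nM to 1500 nM. The expected step of a 2.1-fold higher number from compound 3 to compound 4 (0.32 log units; beyond the scatter) lies within the scatter.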

Compound 4, inhibition constant: 525 nM
For compound 4 the middle estimate is 1.8-fold (0.24 log units) below the measured one; measured number inside the range.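

In this assay, within the data shown here, amino in place of hydroxy on the aromatic carbon gives a 3.6-fold higher number from compound 3 to compound 4 (0.56 log units; beyond the scatter) and is the first step that can be sized. The two groups match in heavy-atom count, hydrogen-bond donors, hydrogen-bond acceptors and net charge, so a readable step appears here with those counts unchanged. The steps from compound 1 and compound 2 to compound 4 cannot be read: the limit of < 10000 nM in this assay, at which 2 of the 4 values shown sit.

Where a methoxy, a methylamino or a fluorine on this carbon would fall relative to compound 3 and compound 4 remains open.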